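A 2,5-dimethylfuran-3-yl group replaces 4-chloro-3-nitrophenyl

The source may report more compounds than this note shows. Statements on the series, on what has been measured and on what is new or still open speak of the compounds shown alone.

In an ADME assay on MT4 cells (Homo sapiens) for cytotoxicity, read by MTT assay (on this read-out lower numbers stand for higher toxicity in this test and higher numbers for lower toxicity in this test), compound 1 (`O=C1c2ccccc2C(=O)N1CCOC(=S)N(C(=O)c1ccc(Cl)c(Cl)c1)c1ccc(Cl)cc1`) gives 35000 nM and compound 2 (`O=C1c2ccccc2C(=O)N1CCOC(=S)N(C(=O)c1ccc(Cl)c([N+](=O)[O-])c1)c1ccc(Cl)cc1`) gives 48000 nM on the same read-out. Among the compounds with values here, the only measured step, nitro in place of chloro on an aromatic carbon, is a 1.4-fold higher number from compound 1 to compound 2 (0.14 log units; within the scatter) and nothing more. Within the data shown here, compound 2 therefore stands level with compound 1, the only other number available.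

Compound 3 (`Cc1cc(C(=O)N(C(=S)OCCN2C(=O)c3ccccc3C2=O)c2ccc(Cl)cc2)c(C)o1`) differs from compound 2 on a carbonyl carbon, with 2,5-dimethylfuran-3-yl in place of 4-chloro-3-nitrophenyl. The counted difference reads 2,5-dimethylfuran-3-yl in place of 4-chloro-3-nitrophenyl on a carbonyl carbon in full. This exchange removes the whole group, whereas the measured step altered only one substituent on it, so that step bears on the question only loosely. Among the measured compounds shown here, no measured compound carries the furan group, and the data give no direction. A step beyond the scatter is therefore not expected, although the uncertainty is wide. The expected change is a 1.2-fold lower number from compound 2 to compound 3 (0.08 log units; within the scatter) in this assay overall. For compound 3 the estimated value is 40000 nM with 15000 nM to 100000 nM as the expected range.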

Compound 3, half-maximal cytotoxic concentration: 40000 nM
Compound 3: the middle estimate sits on the measured number at the digits printed; measured number inside the range.
By their numbers in this assay, from the lowest: compounds 1, 3 and 2 (each within the scatter of the next).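

In this assay, replacing the whole aromatic group on the carbonyl carbon gives a 1.2-fold lower number from compound 2 to compound 3 (0.08 log units; within the scatter), and the corresponding exchange of 3,4-dichlorophenyl for 2,5-dimethylfuran-3-yl gives a 1.1-fold higher number from compound 1 to compound 3 (0.06 log units; within the scatter). The earlier pair spoke only to one substituent on a six-membered aromatic ring of carbon only, whereas these steps show that in this test a five-membered aromatic ring with 1 hetero atom can take the place of that ring, without a step beyond the scatter from either phenyl compound. Nothing available explains why the read-out stays level across this exchange.

All steps among these compounds stay within the scatter, so it remains open whether any group on this carbonyl carbon, such as an amine, a carboxylic acid or a saturated cyclohexyl ring, would give a step beyond it. On these data alone, what a change elsewhere in the shared core would do to the read-out, and whether the level numbers would hold for another furan substitution, such as an unsubstituted furan-3-yl group, also stay open.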